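Allyl for dimethylallyl on a nitrophenyl phenol

A few compounds are considered here, and "the series" means these few. Any claim that something is new, unique, unknown or untested is made for them only; others in the source may bear on it.

Compound 1 `C=CCc1cc(-c2ccc(OC)cc2)cc(CC=C)c1O`: 75600 nM
Compound 2 `C=CC(C)(C)c1cc(-c2cccc([N+](=O)[O-])c2)ccc1O`: 64000 nM
Compound 3 `C=CC(C)(C)c1cc(-c2ccc(OC)cc2)ccc1O`: > 100000 nM

In a functional assay on A549 cells (Homo sapiens) for antiproliferative activity, read by MTT assay, with a stated time of 24 h (a lower number here means a stronger inhibitor, a higher number a weaker inhibitor), compound 2 gives 64000 nM. Compound 1 in this assay gives 75600 nM, and the two numbers lie within the scatter of each other, so no order can be read between them. Compound 3 returns only a limit, (the limit of > 100000 nM in this assay, at which 1 of the 3 values shown sits), so its value is not a number. Compound 4 `C=CCc1cc(-c2cccc([N+](=O)[O-])c2)ccc1O` has not yet been measured in this assay. It differs from compound 2 in one place: allyl in place of 1,1-dimethylprop-2-en-1-yl on an aromatic carbon. Within the data shown here, no measured pair shows this change on its own, so the size of its effect is not known here. The step from compound 2 to compound 4 is expected to be a 1.2-fold lower number from compound 2 to compound 4 (0.07 log units; within the scatter), within the scatter. Compound 4 is therefore estimated at 55000 nM, between 20000 nM and 150000 nM.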

Compound 4, half-maximal inhibitory concentration: > 100000 nM
Compound 4: a limit, no number; the forecaster's own chance of this, stated with the estimate: 30%; middle value at least 1.8-fold (0.25 log units) away from the limit.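

In this assay compound 4 gives a limit and not a number, the second compound shown to do so: the limit of > 100000 nM in this assay, at which 2 of the 4 values shown sit. Among these compounds, the pair gives the first reading of allyl in place of 1,1-dimethylprop-2-en-1-yl on this aromatic carbon, ortho to a hydroxy group, as an at least 1.5-fold higher number from compound 2 to compound 4 (0.19 log units; that floor lies within the scatter) and only this floor can be read. At this position, allyl gives no lower number than 1,1-dimethylprop-2-en-1-yl.

Going by these compounds, the true size of the step stays open. So does whether an amine, a carboxylic acid or a longer chain on this carbon would give a measurable number.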